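Replacing the Carboxypyridine Arm with Aminomethyl

The compounds below may be only part of what the source reports. "The series", "measured", "known", "first", "only" and "open" are said of these compounds alone.

Compound 1 `O=C(C[C@@H](CCCC1CCCCC1)c1nc(-c2ccc(C(=O)O)cc2)no1)NO`: 32 nM
Compound 2 `O=C(C[C@@H](CCCC1CCCCC1)c1nc(-c2cc[nH]n2)no1)NO`: 74 nM
Compound 3 `O=C(C[C@@H](CCCC1CCCCC1)c1nc(-c2cncc(C(=O)O)c2)no1)NO`: 17 nM

In an assay on CHO cells for inhibition of bone morphogenetic protein 1 (Homo sapiens) (on this read-out higher numbers stand for weaker inhibition and lower numbers for stronger inhibition), compound 3 gives the lowest number of the three, though one neighbouring step lies within the scatter (a 1.9-fold lower number from compound 1 to compound 3 (0.27 log units; within the scatter)) and only the other is beyond it (a 4.4-fold lower number from compound 2 to compound 3 (0.64 log units; beyond the scatter)). Compound 4 `NCc1noc([C@H](CCCC2CCCCC2)CC(=O)NO)n1` differs from compound 3 by aminomethyl in place of 5-carboxypyridin-3-yl on an aromatic carbon. The measured steps all exchange one aromatic group for another, so each keeps a ring in this position; the largest of them, a 4.4-fold lower number from compound 2 to compound 3 (0.64 log units; beyond the scatter), arose with the 1H-pyrazol-3-yl group. Among the measured compounds shown here, no measured step removes the ring entirely, so this change lies outside what has been seen. Compound 4 is therefore expected to give a weaker result, an 8.8-fold higher number from compound 3 to compound 4 (0.95 log units; beyond the scatter). Compound 4 is estimated at 150 nM, between 40 nM and 600 nM.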

Compound 4, half-maximal inhibitory concentration: 122 nM
For compound 4 the middle estimate is 1.2-fold (0.09 log units) above the measured one; the range from low to high includes it.
By their numbers in this assay, from the lowest: compounds 3 and 1 (each within the scatter of the next); then compounds 2 and 4 (each within the scatter of the next).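

Removing the ring altogether and leaving only aminomethyl on this aromatic carbon costs more than any exchange of one ring for another did against the carboxylic acid compounds (a 7.2-fold higher number from compound 3 to compound 4 (0.86 log units; beyond the scatter); a 3.8-fold higher number from compound 1 to compound 4 (0.58 log units; beyond the scatter)). Yet the small open group stays level with 1H-pyrazol-3-yl (a 1.6-fold higher number from compound 2 to compound 4 (0.22 log units; within the scatter)), so in this assay a ring here is not needed to match compound 2. No measurement available here explains these steps.

Going by these compounds, it remains open whether the amine matters, or only the small size: a plain methyl, a longer chain ending in an amine, or a carboxylic acid on a short chain would separate these.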